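Benzyl in place of phenyl: a permeability estimate

The source may report more compounds than this note shows. Statements on the series, on what has been measured and on what is new or still open speak of the compounds shown alone.

In an ADME assay on Caco-2 cells (Homo sapiens) for permeability, read by LC-MS, in the apical to basolateral direction, with a stated time of 60 min, at pH 6.5 (a higher number here means that the compound crosses the layer faster, a lower number that the compound crosses the layer more slowly), compound 1 (`O=C(NCc1cc(Cl)ccc1-n1cnnn1)[C@@H]1C[C@@H]2C[C@@H]2N1C(=O)[C@H](O)Cn1cccn1`) gives 0.45 10^-6 cm/s and compound 2 (`O=C(NCc1cc(Cl)ccc1-n1cnnn1)[C@@H]1CC=NN1C(=O)[C@H](O)c1ccccc1`) gives 7 10^-6 cm/s as the higher of the two numbers, a gap beyond the usual scatter of repeat measurements. Compound 3 (`O=C(NCc1cc(Cl)ccc1-n1cnnn1)[C@@H]1CC=NN1C(=O)[C@H](O)Cc1ccccc1`) departs from compound 2 in one place, on a saturated chain carbon bound to a carbonyl carbon and an oxygen on a saturated carbon, where benzyl stands in place of phenyl (benzyl in place of phenyl on a saturated chain carbon bound to a carbonyl carbon and an oxygen on a saturated carbon) and hydroxy(phenyl)methyl thus becomes 1-hydroxy-2-phenylethyl. For the measured compounds named here, no measured pair shows this kind of change, so the expectation rests on the structural change alone. The step of a 1.2-fold lower number from compound 2 to compound 3 (0.07 log units; within the scatter) is expected to stay within the scatter in this assay with no clear direction. Compound 3 is estimated at 6 10^-6 cm/s with an expected range of 2.5 10^-6 cm/s to 14 10^-6 cm/s in this measurement.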

Compound 3, apparent permeability: 11 10^-6 cm/s
Compound 3: middle estimate off by 1.8-fold (0.26 log units), on the low side; the range from low to high includes it.
By their numbers in this assay, from the lowest: compound 1; then compounds 2 and 3 (each within the scatter of the next).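

For the compounds shown here, at this position, on a saturated chain carbon bound to a carbonyl carbon and an oxygen on a saturated carbon, this assay gives the first direct reading of benzyl in place of phenyl: a 1.6-fold higher number from compound 2 to compound 3 (0.20 log units; within the scatter). Going by these compounds alone, the earlier compounds included no pair differing in this one place, so this step is the first to show that hydroxy(phenyl)methyl can become 1-hydroxy-2-phenylethyl on this core without a change beyond the scatter. Nothing measured here explains this outcome.

As far as these compounds go, it remains open whether a longer chain, such as 3-phenylpropyl, or a phenyl ring carrying an amine or a carboxylic acid would also keep the reading within the scatter at this position. This single step also cannot say whether the same change would read alike on the core of compound 1.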